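A few compounds are considered here, and "the series" means these few. Any claim that something is new, unique, unknown or untested is made for them only; others in the source may bear on it.

Measured so far in a functional assay on MCF7 cells (Homo sapiens) for antiproliferative activity, read by MTT assay, with a stated time of 48 h; a higher number here means a weaker inhibitor, a lower number a stronger inhibitor:
- compound 1 `Cc1ccc(-c2nn(-c3ccccc3)cc2C(Nc2nc3cc(C)c(C)cc3s2)c2c(O)ccc3ccccc23)cc1`: 22400 nM
- compound 2 `Oc1ccc2ccccc2c1C(Nc1nc2ccccc2s1)c1cn(-c2ccccc2)nc1-c1cccc(Cl)c1`: 20700 nM
- compound 3 `COc1ccc2nc(NC(c3cn(-c4ccccc4)nc3-c3ccc(Cl)cc3)c3c(O)ccc4ccccc34)sc2c1`: 23700 nM

Compound 3, at 23700 nM, lies within the scatter of both other compounds, so the three values cannot be told apart. The next compound, compound 4 `COc1ccc2nc(NC(c3cn(-c4ccccc4)nc3-c3cccc([N+](=O)[O-])c3)c3c(O)ccc4ccccc34)sc2c1`, keeps the shared core of compound 3 and has 3-nitrophenyl in place of 4-chlorophenyl on an aromatic carbon of a five-membered aromatic ring with 2 nitrogen: 3-nitrophenyl in place of 4-chlorophenyl on an aromatic carbon.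

Among the measured compounds shown here, no two measured compounds differ in one place only, so the data offer no direct measure of a single change. The closest guide is the narrow spread of the set. Compound 1 at 22400 nM and compound 2 at 20700 nM differ from compound 3 in the aromatic group at this same carbon and elsewhere, yet their values remain within the scatter of its value. On that limited evidence, no change beyond the scatter is expected in this assay, and no direction can be argued with confidence. The estimated step is small: a 1.2-fold lower number from compound 3 to compound 4 (0.07 log units; within the scatter). Compound 4 is expected at 20000 nM, with an estimated range of 9000 nM to 40000 nM.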

Compound 4, half-maximal inhibitory concentration: 26800 nM
Compound 4: the middle estimate sits 1.3-fold (0.13 log units) below what was measured; the range from low to high includes it.
By their numbers in this assay, from the lowest: compounds 2, 1, 3 and 4 (each within the scatter of the next).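

In this assay, among the compounds shown here, the first comparison in which only one place differs gives a 1.1-fold higher number from compound 3 to compound 4 (0.05 log units; within the scatter). On the shared core of compound 3, this aromatic carbon of the five-membered ring therefore accepts 3-nitrophenyl in place of 4-chlorophenyl with no change that can be told from the scatter, even though the entering group has 9 heavy atoms against 7 and 2 hydrogen-bond acceptors against 0. No measurement is available that would explain this result or link it to any property of either group.

For the compounds shown here, since the change replaces chlorine with a nitro group and also alters the printed name from a 4-substituted to a 3-substituted phenyl, this single step cannot separate the two differences, and it covers only one pair on one core. As far as these compounds go, whether an amine or a carboxylic acid on the phenyl ring at this carbon, or a small alkyl chain in place of the ring, would move the number beyond the scatter remains open.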